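The source may hold more compounds than are shown below. What is called first, only, known or untested is meant among the compounds shown, and "the series" means these compounds.

Measured compounds:
Compound 1, `CCCCCC[C@H](C)[C@@H]1CC(=O)NCC(=O)N[C@@H](C(C)C)C(=O)N[C@H](CC(C)C)C(=O)N[C@@H](C)C(=O)N[C@@H](CC(C)C)C(=O)O1`, gives 25700 nM in a functional assay on HeLa cells (Homo sapiens) for cytotoxicity, read by MTT assay, with a stated time of 48 h; on this read-out higher numbers stand for weaker inhibition and lower numbers for stronger inhibition.
Compound 2, `CCCCCC[C@H](C)[C@@H]1CC(=O)NCC(=O)N[C@@H](C(C)C)C(=O)N[C@H](CC(C)C)C(=O)N[C@@H](C)C(=O)N[C@@H](Cc2ccc(O)cc2)C(=O)O1`, gives 12400 nM in this assay.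

Compound 2 stands lowest of the two numbers; its nearest neighbour, compound 1, differs by a 2.1-fold lower number from compound 1 to compound 2 (0.32 log units; beyond the scatter). Compound 3, `CCCCCC[C@H](C)[C@@H]1CC(=O)NCC(=O)N[C@@H](C(C)C)C(=O)N[C@H](CC(C)C)C(=O)N[C@@H](C)C(=O)N[C@@H](CCSC)C(=O)O1`, has not been measured. It differs from compound 2 by (methylsulfanyl)methyl in place of 4-hydroxyphenyl on a saturated chain carbon bound to a saturated ring carbon. Going by the values given here, only the step of a 2.1-fold lower number from compound 1 to compound 2 (0.32 log units; beyond the scatter) bears on this change, and it was modest. Compound 3 carries neither of the two side chains seen so far, so a number between those of compound 1 and compound 2 is expected, a 1.5-fold higher number from compound 2 to compound 3 (0.19 log units; within the scatter). The estimate for compound 3 is therefore 19000 nM, within 8000 nM to 50000 nM.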

Compound 3, half-maximal inhibitory concentration: 31300 nM
Compound 3: the middle estimate sits 1.6-fold (0.22 log units) below what was measured; measured number inside the range.
By their numbers in this assay, from the lowest: compound 2; then compounds 1 and 3 (each within the scatter of the next).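

In this assay, 2-(methylsulfanyl)ethyl in place of 4-hydroxybenzyl gives a 2.5-fold higher number from compound 2 to compound 3 (0.40 log units; beyond the scatter) and so takes away the modest advantage seen with the 4-hydroxyphenyl group. With (methylsulfanyl)methyl in place of isopropyl, the change is a 1.2-fold higher number from compound 1 to compound 3 (0.09 log units; within the scatter) and does not separate the two, so at this position only compound 2 stands apart. No evidence at hand explains this difference.

On these data alone, it remains open whether the aromatic ring or its hydroxyl accounts for the difference. A phenyl group without the hydroxyl, or a 4-aminophenyl group, would separate the two.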